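An Ethyl-to-Trifluoromethyl Swap in a Receptor Binding Series

The source may hold more compounds than are shown below. What is called first, only, known or untested is meant among the compounds shown, and "the series" means these compounds.

Of the compounds shown here, two sharing one core have so far been tested in an assay on isolated protein for binding affinity to corticotropin-releasing factor receptor 1 (Homo sapiens); a higher number here means a weaker inhibitor, a lower number a stronger inhibitor. Compound 1 `Cc1ccc(NC(C(=O)CCc2ccccc2)c2ccccc2Br)c(Cl)c1` gives only a limit in this assay, > 10000 nM, so no number is attached to it. Compound 2 `CCc1ccccc1C(Nc1ccc(Cl)cc1Cl)C(=O)CCc1ccncc1` gives a measured value of 330 nM in this assay. Compound 2 therefore holds the only real number among the results shown, the other result sitting at the limit of the assay (the limit of > 10000 nM in this assay, at which 1 of the 2 values shown sits).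

Compound 3 `O=C(CCc1ccncc1)C(Nc1ccc(Cl)cc1Cl)c1ccccc1C(F)(F)F` has not yet been measured. It differs from compound 2 in a single place: trifluoromethyl in place of ethyl on an aromatic carbon. For the measured compounds named here, no pair of measured compounds shows how this kind of exchange shifts binding, so any expectation rests on compound 2 alone. The exchange touches only a few atoms, as the counted difference shows, and the step of a 1.2-fold higher number from compound 2 to compound 3 (0.08 log units; within the scatter) is expected to stay within the usual scatter, with no clear direction. Compound 3 is expected to give about 400 nM in this assay, with a likely range from 120 nM to 1300 nM.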

Compound 3, inhibition constant: 1000 nM
The estimate for compound 3 lay 2.5-fold (0.40 log units) below the measured number; low and high end bracket the measured number.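

Trifluoromethyl in place of ethyl on this aromatic carbon, ortho to a large group, is the first exchange in the series that can be read as a step, and in this assay it gives a 3.0-fold higher number from compound 2 to compound 3 (0.48 log units; beyond the scatter) as a modest change toward weaker binding. Small as the exchange is, the step lies beyond the scatter, so what sits at this one place on the ring does register in the read-out, and here the ethyl-bearing compound 2 is the better of the two. The change does not abolish binding, however, since compound 3 still gives a real number, 1000 nM in this assay, and not a limit, so the position accepts trifluoromethyl with only a modest loss.

Still open, going by these compounds, is how other groups at this place would compare, such as a methoxy group, an amine or a longer chain, and whether any of them would give a lower number than ethyl does. Nothing in the results shown explains why this exchange gives a higher number.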